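The source may report more compounds than this note shows. Statements on the series, on what has been measured and on what is new or still open speak of the compounds shown alone.

Measured so far in a functional assay on HeLa cells (Homo sapiens) for inhibition, read by MTT assay, with a stated time of 48 h; a lower number here means a stronger inhibitor, a higher number a weaker inhibitor:
compound 1, `CN1CCN(c2ccc(Nc3ncc4c(n3)N(C3CCCC3)CC(=O)N4)cc2)CC1`, gives 21300 nM.
Compound 2, `O=C1CN(C2CCCC2)c2nc(Nc3ccc(N4CCCCC4)cc3)ncc2N1`, gives only a limit of the assay, > 30000 nM.
Compound 3, `CC1CCN(c2ccc(Nc3ncc4c(n3)N(C3CCCC3)CC(=O)N4)cc2)CC1`, also gives only a limit of the assay, > 30000 nM.

Among the measured compounds shown here, compound 1 thus stands as the one compound with a number in this assay; the other two rest at the limit of > 30000 nM in this assay, at which 2 of the 3 values shown sit. The step of an at least 1.4-fold higher number from compound 1 to compound 2 (0.14 log units; that floor lies within the scatter) and the step of an at least 1.4-fold higher number from compound 1 to compound 3 (0.14 log units; that floor lies within the scatter) both lead from that number into a limit, and the step that the two limits leave unreadable from compound 2 to compound 3 connects two limits.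

Compound 4, `CN1CCN(c2ccc(Nc3ncc4c(n3)N(C3CCCC3)CC(=O)N4C)cc2)CC1`, differs from compound 1 in a single place: methyl in place of hydrogen on an amide-type nitrogen in a ring. For the measured compounds named here, none of the measured steps touches this position. Going by the values given here, the only exchange of a methyl for a hydrogen among them, the step that the two limits leave unreadable from compound 2 to compound 3, sits on a saturated ring carbon and gives no readable size. The expectation for compound 4 therefore rests on compound 1 alone, and a weak inhibitor is anticipated. Compound 4 is expected at about 25000 nM, with a range from 8000 nM to 80000 nM. This estimate corresponds to a step of a 1.2-fold higher number from compound 1 to compound 4 (0.07 log units; within the scatter), expected to stay within the scatter.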

Compound 4, half-maximal inhibitory concentration: 6750 nM
The estimate for compound 4 lay 3.7-fold (0.57 log units) above the measured number; the whole stated range lies above it.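

In this assay, among the compounds shown here, methyl in place of hydrogen on this amide-type nitrogen gives a 3.2-fold lower number from compound 1 to compound 4 (0.50 log units; beyond the scatter) and so provides the first step in this set that is both readable in size and beyond the scatter. The amide hydrogen of compound 1 is therefore not required for the inhibition read here, and adding a single carbon at this position moves the number in the stronger direction. Compound 2 and compound 3, which both keep the amide hydrogen, remain at a limit of the assay rather than a number: the limit of > 30000 nM in this assay, at which 2 of the 4 values shown sit.

The compounds shown leave open whether the lower number is particular to methyl on this nitrogen or would also come with an ethyl group, a longer chain or a chain ending in an amine. They also leave open why the number falls, and whether the same exchange would bring a measurable number with piperidin-1-yl or 4-methylpiperidin-1-yl in place of the 4-methylpiperazin-1-yl group.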